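Swapping Pentan-3-yl for 4-Fluorobenzyl on the Core

The source may hold more compounds than are shown below. What is called first, only, known or untested is meant among the compounds shown, and "the series" means these compounds.

In an ADME assay on HepG2 cells (Homo sapiens) for cytotoxicity, read by luminescence, CellTiter-Glo and ATP content, with a stated time of 72 h (a higher number here means that more compound is needed for the effect, a lower number that less compound is needed), compound 1 `CCC(CC)c1ccc2c(NCCCNCc3cc(F)ccc3OC)ccnc2c1` gives 7860 nM, and compound 2 `CCC(CC)c1ccc2c(NCCCNCc3ccco3)ccnc2c1` gives 6760 nM; the two lie within the scatter of each other. Within the data shown here, the only measured step, a 1.2-fold lower number from compound 1 to compound 2 (0.07 log units; within the scatter), concerns the group on a saturated chain carbon bound to an amine nitrogen. Compound 3 `COc1ccc(F)cc1CNCCCNc1ccnc2cc(Cc3ccc(F)cc3)ccc12` differs elsewhere: 4-fluorobenzyl in place of pentan-3-yl on an aromatic carbon. Among the measured compounds shown here, no measured step touches this aromatic carbon, so the known step says little about it, and no change beyond the scatter is expected. The step of a 1.0-fold higher number from compound 1 to compound 3 (0.01 log units; within the scatter) is therefore estimated to be small. Compound 3 is expected at 8000 nM, between 3500 nM and 18000 nM.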

Compound 3, half-maximal effective concentration: 3530 nM
Beside the measured number, compound 3's estimate is 2.3-fold (0.36 log units) above it; low and high end bracket the measured number.
By their numbers in this assay, from the lowest: compounds 3, 2 and 1 (each within the scatter of the next, the first and the last beyond it).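

This aromatic carbon matters more in this assay than the chain position did: placing 4-fluorobenzyl there instead of pentan-3-yl gives a modest step beyond the scatter (a 2.2-fold lower number from compound 1 to compound 3 (0.35 log units; beyond the scatter)). The earlier change on the chain stayed within the scatter. No available evidence bears on the reason for this step.

From the compounds shown here alone, whether a plain benzyl, a cyclohexyl or a carboxylic acid on this carbon would give a similar number stays open. So does whether furan-2-yl on the chain would behave the same alongside 4-fluorobenzyl.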